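Lengthening the hydroxamate chain on the unsubstituted core

This account rests on a few compounds, and the source may have more. Where it says the series, first, only, none or still open, it means among the compounds named here.

Compound 1 `CS(=O)(=O)c1ccc2nc(NC(=O)CCCCC(=O)NO)sc2c1`: in a functional assay on NCI-H460 cells (Homo sapiens) for cytotoxicity (a lower number here means a stronger inhibitor, a higher number a weaker inhibitor), compound 1 gives > 30 ug/mL, which is a limit of the assay rather than a number.
Compound 2 `COc1ccc2nc(NC(=O)CCCCCCC(=O)NO)sc2c1`: compound 2 gives 1.25 ug/mL.
Compound 3 `O=C(CCCCC(=O)Nc1nc2ccccc2s1)NO`: compound 3 gives 14.4 ug/mL.

Among the numbers shown, compound 3 stands highest; its nearest neighbour is compound 2, whose number is lower by a margin beyond the usual scatter. Within the data shown here, the one measured step, an at least 2.0-fold lower number from compound 1 to compound 3 (0.31 log units; beyond the scatter), concerns a ring substituent and leaves the chain untouched. Compound 4 `O=C(CCCCCCC(=O)Nc1nc2ccccc2s1)NO` differs from compound 3 by 2-(hydroxycarbamoyl)ethyl in place of hydroxycarbamoyl on a saturated chain carbon, four bonds along the chain from a carbonyl carbon. Compound 2 carries the longer chain together with a methoxy group, so its lower number cannot be split between the two changes. Even so, a lower number is expected for compound 4, with a step of a 5.8-fold lower number from compound 3 to compound 4 (0.76 log units; beyond the scatter). Compound 4 is estimated at 2.5 ug/mL, between 0.8 ug/mL and 8 ug/mL.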

Compound 4, half-maximal inhibitory concentration: 5.71 ug/mL
Beside the measured number, compound 4's estimate is 2.3-fold (0.36 log units) below it; the range from low to high includes it.
By their numbers in this assay, from the lowest: compound 2; then compound 4; then compound 3. At a limit, above all of these: compound 1.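

In this assay, lengthening the chain alone, with 2-(hydroxycarbamoyl)ethyl in place of hydroxycarbamoyl, gives a 2.5-fold lower number from compound 3 to compound 4 (0.40 log units; beyond the scatter) on the unsubstituted core, so the longer chain lowers the number without help from a ring substituent. At this same chain length, hydrogen in place of methoxy gives a 4.6-fold higher number from compound 2 to compound 4 (0.66 log units; beyond the scatter) and shows that the methoxy group also matters to the low number of compound 2. Nothing measured here explains either step. From the compounds shown here alone, whether a still longer chain lowers the number further remains open. So does the effect of an amine or a carboxylic acid on the ring.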